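Methyl in place of chloro: compound 2 to compound 3

The source may hold more compounds than are shown below. What is called first, only, known or untested is meant among the compounds shown, and "the series" means these compounds.

Measured in an ADME assay on microsomes from liver (Homo sapiens) for metabolic stability (a lower number here means slower removal, a higher number faster removal of the compound), with both values as limits of the assay:
- compound 1 (`Cc1cccnc1N(C(=O)N1CCC(c2ccccc2F)CC1)[C@@H]1CCCNC1`) gives < 8 mL.min-1.g-1 as a limit
- compound 2 (`O=C(N1CCC(c2cnn3cccnc23)CC1)N(c1ncccc1Cl)[C@@H]1CCCNC1`) gives < 8 mL.min-1.g-1 as a limit

In this assay compound 2 gives < 8 mL.min-1.g-1 as a limit and not a number. Among the compounds with values here, the only other value sits at that same limit (the limit of < 8 mL.min-1.g-1 in this assay, at which 2 of the 2 values shown sit).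

Compound 3 (`Cc1cccnc1N(C(=O)N1CCC(c2cnn3cccnc23)CC1)[C@@H]1CCCNC1`) has methyl in place of chloro on an aromatic carbon, ortho to a large group, so that 3-chloropyridin-2-yl becomes 3-methylpyridin-2-yl.

Within the data shown here, no measured step covers this exchange. Compound 1 also carries 3-methylpyridin-2-yl and gives < 8 mL.min-1.g-1 as a limit. No change beyond the scatter is expected and no direction can be named, so the estimated move is small (a step that the limit leaves unreadable from compound 2 to compound 3). For compound 3 the estimate is 7 mL.min-1.g-1 with an expected range from 4 mL.min-1.g-1 to 14 mL.min-1.g-1 and a report as a limit is likely.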

Compound 3, intrinsic clearance in microsomes in the Homo sapiens assay: < 8 mL.min-1.g-1
Compound 3 was reported as a limit; the forecaster's own chance of this, stated with the estimate: 70%; the middle value lies beyond the limit too.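

Within the data shown here, in the Homo sapiens assay compound 1, compound 2 and compound 3 all stand at a limit of the assay, so no step among them can be read: the limit of < 8 mL.min-1.g-1 in the Homo sapiens assay, at which 3 of the 3 values shown sit. In the Homo sapiens assay compound 3 gives < 8 mL.min-1.g-1, a limit of the assay and not a number. From the compounds shown here alone, whether methyl in place of chloro shifts intrinsic clearance in microsomes at all stays open. In a physicochemical assay for lipophilicity, using the shake flask method (a higher number here means a more lipophilic compound, a lower number a more polar compound), compound 2 gives -0.5 and compound 3 gives 0.2.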